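Methyl for Methoxy on the Benzoyl Ring

A few compounds are considered here, and "the series" means these few. Any claim that something is new, unique, unknown or untested is made for them only; others in the source may bear on it.

Measured compounds:
compound 1, `COC(=O)c1c(Nc2ccccc2)sc(C(=O)c2ccc(C)cc2)c1C`: 4.59%
compound 2, `COc1ccc(C(=O)c2sc(Nc3ccccc3)c(C(=O)O)c2C)cc1`: 36.5%
compound 3, `COc1ccc(C(=O)c2sc(Nc3ccc(C)cc3)c(C(=O)O)c2C)cc1`: "not active" (no number reported)

In a functional assay, with a stated time of 150 min, tested at 15 ug/mL (a higher number here means a stronger effect of the compound at the concentration tested, a lower number a weaker effect), compound 2 gives 36.5%, the highest of the two numbers reported, with compound 1 at 4.59% lying well beyond the scatter below it. For compound 3 only "not active" (no number reported) is reported, without a number. Compound 4, `Cc1ccc(C(=O)c2sc(Nc3ccccc3)c(C(=O)O)c2C)cc1`, has not been measured in this assay. It differs from compound 2 in one place: methyl in place of methoxy on an aromatic carbon. Among the measured compounds shown here, no step between measured compounds isolates this change, so its size cannot be read from the data. Since compound 2 gives 36.5%, compound 4 is expected to show a moderate decrease, a number 14.5 percentage points lower from compound 2 to compound 4 (beyond the scatter). The estimate for compound 4 is 22%, in the range 5% to 40%.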

Compound 4, a percentage reported as activity, at one concentration (the size of the read-out at that concentration, not a potency): 1.25%
The estimate for compound 4 lay 20.8 percentage points above the measured number; measured number below the stated range.
By their numbers in this assay, from the lowest: compounds 4 and 1 (each within the scatter of the next); then compound 2.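

Replacing methoxy with methyl on the aromatic carbon para to a large group gives a number 35.3 percentage points lower from compound 2 to compound 4 (beyond the scatter) in this assay and shows that the read-out is highly sensitive to this substituent. With methyl at that place, hydrogen in place of methyl on the oxygen next to the carbonyl group gives a number 3.3 percentage points lower from compound 1 to compound 4 (within the scatter) and leaves the methyl ester and the carboxylic acid unseparated. Nothing available explains the size of the methoxy-to-methyl step.

As far as these compounds go, whether an ethoxy group, a hydroxyl or an amine in place of methoxy would keep the read-out of compound 2 stays open. So does whether the ester and the acid would also remain unseparated with methoxy on the ring.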